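This account rests on a few compounds, and the source may have more. Where it says the series, first, only, none or still open, it means among the compounds named here.

Compound 1 `O=C(Nc1cc(Nc2ccc(Cl)cc2)ncn1)c1ccc(F)cc1`: 820 nM
Compound 2 `O=C(O)CCC(=O)Nc1cc(Nc2ccc(Cl)cc2)ncn1`: 790 nM

Both values come from a functional assay on PC-9 cells (Homo sapiens) for antiproliferative activity, read by MTT assay, with a stated time of 72 h; a lower number here means a stronger inhibitor, a higher number a weaker inhibitor. The two numbers sit together, with a 1.0-fold lower number from compound 1 to compound 2 (0.02 log units; within the scatter). For the measured compounds named here, compound 2 is therefore level with the only other measured compound, and neither stands apart.

Compound 3 `Clc1ccc(Nc2cc(Nc3cccc(Cl)n3)ncn2)cc1` is not yet measured. It carries 6-chloropyridin-2-yl in place of (2-carboxyethyl)carbonyl on a nitrogen on an aromatic ring.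

Going by the values given here, only that single measured step bears on this change, and only loosely. It exchanged 4-fluorophenyl for 2-carboxyethyl on a carbonyl carbon, and its size lay within the scatter. Compound 3 has no such carbonyl at this nitrogen, so no measurement covers the present replacement directly. The data point in neither direction, so no shift beyond the scatter is expected in this assay, although the uncertainty is wide. The expected step is a 1.0-fold higher number from compound 2 to compound 3 (0.01 log units; within the scatter). For compound 3 the estimated value is 800 nM, with an expected range from 200 nM to 3200 nM.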

Compound 3, half-maximal inhibitory concentration: 1180 nM
Beside the measured number, compound 3's estimate is 1.5-fold (0.17 log units) below it; low and high end bracket the measured number.
By their numbers in this assay, from the lowest: compounds 2, 1 and 3 (each within the scatter of the next).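

Until compound 3, both measured compounds carried a carbonyl on this nitrogen, so the earlier step had only exchanged what lay beyond that carbonyl. In this assay the present change removes the carbonyl and the whole (2-carboxyethyl)carbonyl group and sets an aromatic ring in their place, with the same count of heavy atoms, yet it gives only a 1.5-fold higher number from compound 2 to compound 3 (0.17 log units; within the scatter) and so shows that, for this pair, neither the carbonyl nor the carboxylic acid of compound 2 is needed for a number in this range. No measurement offered here explains why the number stays within the scatter across so large a change in the group on this nitrogen.

The compounds shown leave open whether the chlorine of the 6-chloropyridin-2-yl group contributes anything, since a plain pyridin-2-yl or a phenyl at this nitrogen would be needed to tell. They also leave open whether a bare amine, a small methyl group or a longer alkyl chain on this nitrogen would move the number beyond the scatter, or whether this position accepts nearly any group.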